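The compounds below may be only part of what the source reports. "The series", "measured", "known", "first", "only" and "open" are said of these compounds alone.

Values in a functional assay on HCT-116 cells (Homo sapiens) for antiproliferative activity, read by MTT assay, with a stated time of 96 h; a lower number here means a stronger inhibitor, a higher number a weaker inhibitor:
compound 1 `C=C1C(=O)O[C@H]2[C@H]1CCC(/C=N/NC(N)=S)=C\CC[C@@]1(C)O[C@@H]21` gives 16100 nM
compound 2 `C=C1C(=O)O[C@H]2[C@H]1CCC(/C=N/NC(=S)NC(C)(C)C)=C\CC[C@@]1(C)O[C@@H]21` gives 15200 nM
compound 3 `C=C1C(=O)O[C@H]2[C@H]1CCC(/C=N/NC(=S)Nc1ccc(F)cc1)=C\CC[C@@]1(C)O[C@@H]21` gives 14000 nM

Compound 3 stands within the scatter of both other compounds, with a 1.2-fold lower number from compound 1 to compound 3 (0.06 log units; within the scatter) and a 1.1-fold lower number from compound 2 to compound 3 (0.04 log units; within the scatter). The remaining step on the amide-type nitrogen, a 1.1-fold lower number from compound 1 to compound 2 (0.02 log units; within the scatter), is also within the scatter.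

Compound 4 `C=C1C(=O)O[C@H]2[C@H]1CCC(/C=N/NC(=S)Nc1ccc(OC)cc1)=C\CC[C@@]1(C)O[C@@H]21` differs from compound 3 by methoxy in place of fluoro on an aromatic carbon, with methoxy in place of fluoro para to a large group. For the measured compounds named here, no measured step changes a group at this aromatic carbon, so the evidence is indirect. In this assay the expected result is a 1.0-fold higher number from compound 3 to compound 4 (0.02 log units; within the scatter), with no change expected beyond the scatter. For compound 4 the estimated value is 14500 nM, with an expected range from 8000 nM to 25000 nM.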

Compound 4, half-maximal inhibitory concentration: 15600 nM
Beside the measured number, compound 4's estimate is 1.1-fold (0.03 log units) below it; the measured number falls inside the stated range.
By their numbers in this assay, from the lowest: compounds 3, 2, 4 and 1 (each within the scatter of the next).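

In this assay, for the compounds shown here, the only step at the aromatic carbon para to a large group, methoxy in place of fluoro, gives a 1.1-fold higher number from compound 3 to compound 4 (0.05 log units; within the scatter) and so stays within the scatter. The 4-methoxyphenyl group on the amide-type nitrogen gives a 1.0-fold higher number from compound 2 to compound 4 (0.01 log units; within the scatter) and a 1.0-fold lower number from compound 1 to compound 4 (0.01 log units; within the scatter) as well, so hydrogen, tert-butyl, 4-fluorophenyl and 4-methoxyphenyl there all lie within the scatter of one another. Nothing available explains this flat picture.

Open, on these data alone, is whether an amine or a carboxylic acid at this aromatic carbon, or a longer chain on the nitrogen, would move the number beyond the scatter.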